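Swapping the amide aryl group in a pyrimidine anilide series

The source may hold more compounds than are shown below. What is called first, only, known or untested is meant among the compounds shown, and "the series" means these compounds.

Of the compounds shown here, two in this set have been measured in a functional assay on NCI-H1975 cells (Homo sapiens) for antiproliferative activity, read by MTT assay, with a stated time of 72 h; a higher number here means a weaker inhibitor, a lower number a stronger inhibitor. Compound 1, `COc1cc(N(C)CCN(C)C)c(NC(=O)c2ccncc2OC)cc1Nc1nccc(-c2cn(C)c3ccccc23)n1`, gives 1010 nM in this assay. Within the data shown here, compound 2, `COc1cc(N(C)C)c(NC(=O)c2ccnc(Cl)c2)cc1Nc1nccc(-c2cn(C)c3ccccc23)n1`, gives 9200 nM in this assay, the higher of the two numbers; compound 1 sits a good way lower, well beyond the usual scatter, but the two structures differ in more than one place, so no single step links them.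

Compound 3, `COc1cc(N(C)C)c(NC(=O)c2ccncc2OC)cc1Nc1nccc(-c2cn(C)c3ccccc23)n1`, has not yet been measured. It is reached from compound 2 by one change: 3-methoxypyridin-4-yl in place of 2-chloropyridin-4-yl on a carbonyl carbon whose other neighbour is an amide-type nitrogen.

Among the measured compounds shown here, no measured pair shows this exact step, so any expectation rests on compound 2 alone and on the general spread of the set. The step from compound 2 to compound 3 is expected to bring the number down, a 3.1-fold lower number from compound 2 to compound 3 (0.49 log units; beyond the scatter), though with wide uncertainty. Compound 3 is estimated at 3000 nM, in a range from 800 nM to 12000 nM.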

Compound 3, half-maximal inhibitory concentration: 12100 nM
For compound 3 the middle estimate is 4.0-fold (0.61 log units) below the measured one; measured number above the stated range.
By their numbers in this assay, from the lowest: compound 1; then compounds 2 and 3 (each within the scatter of the next).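

In this assay, 3-methoxypyridin-4-yl and 2-chloropyridin-4-yl on a carbonyl carbon whose other neighbour is an amide-type nitrogen cannot be told apart in this setting, with a 1.3-fold higher number from compound 2 to compound 3 (0.12 log units; within the scatter). The new compound also gives the set its first single-place comparison at the other site: with the 3-methoxypyridin-4-yl amide held constant, hydrogen in place of (dimethylamino)methyl on a saturated chain carbon bound to a nitrogen on an aromatic ring goes with a large step in the opposite sense to the one the amide swap was expected to take, a 12-fold higher number from compound 1 to compound 3 (1.08 log units; beyond the scatter), so among these compounds the number moves at the chain and not at the amide aryl group. Nothing measured alongside these numbers offers an explanation for either step.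

As far as these compounds go, whether the two pyridinyl groups would still read alike with the (dimethylamino)methyl group in place stays open, as the amide swap is seen here only on compounds without it. Also open, from the compounds shown here alone, is how a morpholine or a piperazine at the end of that chain, or a plain phenyl on the carbonyl carbon, would read.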